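The source may report more compounds than this note shows. Statements on the series, on what has been measured and on what is new or still open speak of the compounds shown alone.

Measured so far in an ADME assay on MDCK cells (Canis lupus familiaris) for cytotoxicity, read by microscopy, with a stated time of 6 days; on this read-out lower numbers stand for higher toxicity in this test and higher numbers for lower toxicity in this test:
- compound 1, `CCCCNc1nccnc1C(=O)NCc1ccccc1`: > 100000 nM
- compound 2, `CCCCCNc1cnc(C(=O)NCc2ccccc2)cn1`: > 100000 nM
- compound 3, `CCCCNc1cncc(C(=O)NCc2ccccc2)n1`: 100000 nM

The value of compound 1 is a limit of this assay, not a number. The value of compound 2 is likewise a limit. Compound 3 gives an actual number, and all three values sit at or beyond (the limit of > 100000 nM in this assay, at which 2 of the 3 values shown sit). Compound 1 therefore stands at the top of what this assay reports, among the least toxic values seen here.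

Compound 4, `CCCCCCCNc1nccnc1C(=O)NCc1ccccc1`, differs from compound 1 by propyl in place of hydrogen on a saturated chain carbon, four bonds along the chain from a nitrogen on an aromatic ring. Within the data shown here, no step between two measured compounds is available to show what such a lengthening does here. For this assay the step of a number no higher from compound 1 to compound 4 (the limit leaves the size open) is expected to stay within the usual scatter, with no clear direction. Compound 4 is thus estimated at 100000 nM, in the range 30000 nM to 100000 nM.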

Compound 4, minimum cytotoxic concentration: 100000 nM
Compound 4: the middle estimate sits on the measured number at the digits printed; low and high end bracket the measured number.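

The value of compound 1, > 100000 nM, is a limit of the assay and not a number. Among these compounds, this gives the first step at this chain position in this assay: putting propyl in place of hydrogen gives a number no higher from compound 1 to compound 4 (the limit leaves the size open), so its size cannot be read. Even so, compound 4 stays at the least toxic end of the values shown, near the edge of what the assay reports: the limit of > 100000 nM in this assay, at which 2 of the 4 values shown sit.

Going by these compounds, whether a still longer chain would give a clearly lower number stays open. So does the effect of an amine or a carboxylic acid on this chain.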